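Same aryl swap on a second core: an expected gain

A few compounds are considered here, and "the series" means these few. Any claim that something is new, unique, unknown or untested is made for them only; others in the source may bear on it.

Compound 1 `Cc1cc(=O)n(-c2ccccc2OC(F)(F)F)nc1C(=O)Nc1ccc(Oc2ncnc3[nH]ccc23)c(F)c1` and compound 2 `Cc1cc(=O)n(-c2ccc(Br)cc2F)nc1C(=O)Nc1ccc(Oc2ncnc3[nH]ccc23)c(F)c1` share one core and differ only in the group on an aromatic nitrogen. In a functional assay on PC-3 cells (Homo sapiens) for cytotoxicity, read by MTT assay, with a stated time of 72 h (a higher number here means a weaker inhibitor, a lower number a stronger inhibitor), compound 1 gives > 60000 nM, which is a limit of the assay rather than a number. Compound 2 gives 13300 nM in this assay. The change between them, (4-bromo-2-fluorophenyl in place of 2-(trifluoromethoxy)phenyl on an aromatic nitrogen), thus brought an at least 4.5-fold lower number from compound 1 to compound 2 (0.65 log units; beyond the scatter); since the starting value is only a limit (the limit of > 60000 nM in this assay, at which 1 of the 3 values shown sits), the full size of that step is not known.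

Compound 3 `Cc1cc(=O)n(-c2ccccc2OC(F)(F)F)nc1C(=O)Nc1ccc(Oc2ncnc3c2ccn3C)cc1` carries the same 2-(trifluoromethoxy)phenyl as compound 1, but on a different core; how the two cores differ is not broken down here. In this assay compound 3 gives 5160 nM, the lowest of the two numbers seen so far. Compound 4 `Cc1cc(=O)n(-c2ccc(Br)cc2F)nc1C(=O)Nc1ccc(Oc2ncnc3c2ccn3C)cc1` has not yet been measured. It differs from compound 3 by 4-bromo-2-fluorophenyl in place of 2-(trifluoromethoxy)phenyl on an aromatic nitrogen, the same change, at the same place, as that made from compound 1 to compound 2.

If the change acts alike on the second core, compound 4 is expected to show a 4.0-fold lower number from compound 3 to compound 4 (0.60 log units; beyond the scatter), an expectation that rests on an at least 4.5-fold lower number from compound 1 to compound 2 (0.65 log units; beyond the scatter) seen for compound 1 and compound 2. Compound 4 is therefore estimated at 1300 nM in this assay. The expected range for compound 4 is estimated to run from 400 nM to 4000 nM, a range kept wide since the earlier step started from a limit (the limit of > 60000 nM in this assay, at which 1 of the 3 values shown sits).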

Compound 4, half-maximal inhibitory concentration: 18800 nM
Estimate against measurement, compound 4: 14-fold (1.16 log units) below; the whole stated range lies below it.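

On the second core the swap to 4-bromo-2-fluorophenyl went the other way in this assay, with a 3.6-fold higher number from compound 3 to compound 4 (0.56 log units; beyond the scatter). The change therefore did not carry over from the core of compound 1 to the core of compound 3, in either direction or size: the same change on two cores in this assay, an at least 4.5-fold lower number (0.65 log units; beyond the scatter) from compound 1 to compound 2 and a 3.6-fold higher number (0.56 log units; beyond the scatter) from compound 3 to compound 4, at least 16-fold (1.21 log units) apart, beyond the scatter of two such steps. This shows that the effect of this aryl swap depends on the core it sits on in these two pairs, but it rests on one pair per core and gives no reason for the reversal, and the size of the first step stays unknown, as compound 1 stands at a limit and not a number: the limit of > 60000 nM in this assay, at which 1 of the 4 values shown sits.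

The compounds shown leave open whether other groups on the aromatic nitrogen, such as an unsubstituted phenyl or a 4-chlorophenyl, would follow the trend of the first core, that of the second, or neither. Also open, on these data alone, is which part of the difference between the two cores goes with the reversal, for instance whether a methyl or a fluorine alone would be enough to turn the step around, and whether the same swap would behave alike on cells other than those used here.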